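The source may report more compounds than this note shows. Statements on the series, on what has been measured and on what is new or still open speak of the compounds shown alone.

Of the compounds shown here, three built on one shared core have been tested in a functional assay on WI-38 VA13 cells (Homo sapiens) for cytotoxicity; on this read-out lower numbers stand for an effect already at smaller amounts and higher numbers for an effect only at larger amounts of compound. Compound 1, `O=C(Nc1ccc2nc(NC(=O)C3CCCCC3)sc2c1)c1ccccc1F`, gives 0.14 ug/mL. Compound 2, `Cc1ccc(F)cc1S(=O)(=O)Nc1ccc2nc(NC(=O)C3CCCCC3)sc2c1`, gives 0.7 ug/mL. Compound 3, `NCCC(=O)Nc1nc2ccc(NC(=O)c3c(Cl)cccc3Cl)cc2s1`, gives 5.3 ug/mL, the highest of the three numbers; its distance to compound 2 and its larger distance to compound 1 both lie beyond the usual scatter of this assay.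

Compound 4, `CCNC(=O)Nc1nc2ccc(NC(=O)c3c(Cl)cccc3Cl)cc2s1`, is the untested partner of compound 3. The two are made of the same atoms joined differently: ethylamino in place of 2-aminoethyl on a carbonyl carbon. Within the data shown here, nothing measured so far shows how this particular rearrangement on the carbonyl carbon, whose other neighbour is an amide-type nitrogen, plays out.

For compound 4 the step expected from the rearrangement is estimated as a 3.5-fold lower number from compound 3 to compound 4 (0.55 log units; beyond the scatter), in the direction of the lower numbers seen for compound 1 and compound 2. Compound 4 is therefore expected to give roughly 1.5 ug/mL in this assay, with a range from 0.4 ug/mL to 5 ug/mL.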

Compound 4, half-maximal effective concentration: 0.032 ug/mL
Compound 4: the middle estimate sits 47-fold (1.67 log units) above what was measured; measured number outside the range, below it.
By their numbers in this assay, from the lowest: compound 4; then compound 1; then compound 2; then compound 3.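

In this assay, this position on the carbonyl carbon, whose other neighbour is an amide-type nitrogen, proves highly sensitive to how the same atoms are joined: ethylamino in place of 2-aminoethyl gives a 170-fold lower number from compound 3 to compound 4 (2.22 log units; beyond the scatter). The two groups have the same count of heavy atoms and hydrogen-bond donors and differ by one hydrogen-bond acceptor, so a step of this size can arise here without any change in the size of the group. Nothing available bears on why the step is so large.

As far as these compounds go, whether propylamino, a longer chain, or morpholine, a cyclic amine, on this carbonyl carbon would give a number nearer that of compound 3 or of compound 4 remains open. From the compounds shown here alone, it also remains open whether the same rearrangement would give a step of similar size with a different group on the other side of the shared core.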